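Phenyl in Place of Pentyl: Expecting Compound 4

The source may report more compounds than this note shows. Statements on the series, on what has been measured and on what is new or still open speak of the compounds shown alone.

Of the compounds shown here, three from this set have been measured in a physicochemical assay for lipophilicity, measured as octanol-water partition; on this read-out lower numbers stand for lower lipophilicity and higher numbers for higher lipophilicity. Compound 1 `CCCCCc1cn(C/C=C(/C)CC/C=C(\C)CCC=C(C)C)nn1` gives 7.5. Compound 3 `CC(C)=CCC/C(C)=C/CC/C(C)=C\Cn1cc(-c2ccccc2)nn1` gives 6.95 in this assay, and the change from compound 1 to compound 3 is phenyl in place of pentyl on an aromatic carbon, which produced the step of a number 0.55 log units lower from compound 1 to compound 3 (beyond the scatter). Compound 2 `CCCCCc1cn(C/C=C(\C)CCC=C(C)C)nn1` gives 5.45 in this assay, the lowest of the three numbers; its values against compound 3 and compound 1 show it well apart from both, beyond the scatter. Compound 2 and compound 1 differ in more than one place, and the difference between the two cores is not broken down here.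

Compound 4 `CC(C)=CCC/C(C)=C/Cn1cc(-c2ccccc2)nn1` has not yet been measured in this assay. It differs from compound 2 by phenyl in place of pentyl on an aromatic carbon, the same change, at the same place, that turns compound 1 into compound 3; among the compounds shown this change occurs twice. Because compound 1 to compound 3 gave a number 0.55 log units lower from compound 1 to compound 3 (beyond the scatter), the step from compound 2 to compound 4 is expected to be of similar size, a number 0.55 log units lower from compound 2 to compound 4 (beyond the scatter), although this expectation rests on one measured pair only and the core of compound 2 is shorter than that of compound 1. Compound 4 is therefore estimated to come in at 4.9 in this assay, with four of five such measurements expected to fall between 4.5 and 5.3.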

Compound 4, partition coefficient: 4.91
The estimate for compound 4 lay 0.01 log units below the measured number; the measured number falls inside the stated range.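

In this assay, the new step (a number 0.54 log units lower from compound 2 to compound 4 (beyond the scatter)) stands close in size to the earlier one (a number 0.55 log units lower from compound 1 to compound 3 (beyond the scatter)), so phenyl in place of pentyl on an aromatic carbon moved the number in the same direction and by a similar amount on both cores. This rests on two pairs only, one on the core of compound 1 and one on the shorter core of compound 2; it shows that the change carried over between these two cores, but it does not show that the step would keep its size on any other core in the series. Nothing given here bears on why the step stayed so similar across the two cores.

The compounds shown leave open how the number responds when other groups stand on that same aromatic carbon, such as a butyl chain, a longer chain, a benzyl group, an amine or a carboxylic acid. They also leave open whether the step from pentyl to phenyl would hold on a core carrying a still longer chain or a saturated one, with no carbon-carbon double bonds.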